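This account rests on a few compounds, and the source may have more. Where it says the series, first, only, none or still open, it means among the compounds named here.

Measured compounds:
compound 1 `O=C(NCCCCC(c1ccc(F)cc1)c1ccc(F)cc1)Nc1ccc(I)cc1` — 11800 nM
compound 2 `O=C(NCCCCC(c1ccc(F)cc1)c1ccc(F)cc1)Nc1ccc([N+](=O)[O-])cc1` — 6470 nM
compound 3 `O=C(NCCCCC(c1ccc(F)cc1)c1ccc(F)cc1)Nc1ccc(Cl)c([N+](=O)[O-])c1` — 4060 nM

In a functional assay on MDA-MB-231 cells (Homo sapiens) for cytotoxicity, read by MTT assay, with a stated time of 48 h (on this read-out higher numbers stand for weaker inhibition and lower numbers for stronger inhibition), compound 1 stands highest of the three: the nearest is compound 2 with a 1.8-fold lower number from compound 1 to compound 2 (0.26 log units; within the scatter), the furthest compound 3 with a 2.9-fold lower number from compound 1 to compound 3 (0.46 log units; beyond the scatter). Compound 2 and compound 3 sit close together, with a 1.6-fold lower number from compound 2 to compound 3 (0.20 log units; within the scatter). Compound 4 `CC(=O)Nc1cc(NC(=O)NCCCCC(c2ccc(F)cc2)c2ccc(F)cc2)ccc1Cl` has not been measured in this assay; it arises from compound 1 by 3-acetamido-4-chlorophenyl in place of 4-iodophenyl on an amide-type nitrogen. Both steps from compound 1 bear on this change, since each also replaces the 4-iodophenyl group, and the larger of them, a 2.9-fold lower number from compound 1 to compound 3 (0.46 log units; beyond the scatter), brings in a 4-chloro-3-nitrophenyl group sharing the chloro of compound 4. A modest lowering is therefore expected, a 2.4-fold lower number from compound 1 to compound 4 (0.37 log units; beyond the scatter). Compound 4 is estimated at 5000 nM, expected to fall between 2500 nM and 12000 nM.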

Compound 4, half-maximal inhibitory concentration: 9120 nM
Compound 4: middle estimate off by 1.8-fold (0.26 log units), on the low side, within the range that was stated.
By their numbers in this assay, from the lowest: compounds 3, 2, 4 and 1 (each within the scatter of the next, the first and the last beyond it).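

In this assay, the 3-acetamido-4-chlorophenyl group on the amide-type nitrogen stays within the scatter of both the 4-iodophenyl group, a 1.3-fold lower number from compound 1 to compound 4 (0.11 log units; within the scatter), and the 4-nitrophenyl group, a 1.4-fold higher number from compound 2 to compound 4 (0.15 log units; within the scatter). Acetamido in place of nitro, with the chloro kept, goes beyond the scatter, a 2.2-fold higher number from compound 3 to compound 4 (0.35 log units; beyond the scatter), so sharing the chloro does not by itself carry over the lower number of compound 3. Nothing available explains this difference. The compounds shown leave open whether an amine in place of the nitro would fall nearer compound 3 or compound 4.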